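The compounds below may be only part of what the source reports. "The series", "measured", "known", "first", "only" and "open" are said of these compounds alone.

Measured compounds:
compound 1 `Cc1c(C)n(C(=O)N2CCCCC2)oc1=O`: 13 nM
compound 2 `Cc1c(C(C)C)c(=O)on1C(=O)N1CCCCC1`: 2 nM
compound 3 `Cc1c(C(C)C)c(=O)on1C(=O)N1CCC(Cc2ccccc2)CC1`: 102 nM

All three numbers come from an assay (strain Wistar) for inhibition of Hormone-sensitive lipase (Rattus norvegicus), read by spectrophotometry; on this read-out lower numbers stand for stronger inhibition and higher numbers for weaker inhibition. Within this set compound 3 gives the highest number; the gap to compound 1 is beyond the scatter, and the gap to compound 2 is wider still, as shown by a 51-fold higher number from compound 2 to compound 3 (1.71 log units; beyond the scatter). The other measured step, a 6.5-fold lower number from compound 1 to compound 2 (0.81 log units; beyond the scatter), concerns the isopropyl on the aromatic carbon and does not touch the saturated ring.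

Compound 4 `Cc1c(C(C)C)c(=O)on1C(=O)N1CCC(c2ccccc2)CC1` has not yet been measured. It differs from compound 3 in one place: phenyl in place of benzyl on a saturated ring carbon. Among the compounds with values here, the only measured step bearing on that place is a 51-fold higher number from compound 2 to compound 3 (1.71 log units; beyond the scatter), which shows that a benzyl on that ring carbon raises the number markedly in this assay. Within the data shown here, compound 4 keeps an aromatic ring there but drops the linking carbon; no measured pair shows what a phenyl alone does at that place, so the size of the step is uncertain. A number between those of compound 3 and compound 2, nearer the former, seems the most reasonable expectation. The expected step is a 2.6-fold lower number from compound 3 to compound 4 (0.41 log units; beyond the scatter), a modest decrease. Compound 4 is estimated at 40 nM in this assay, with a range of 10 nM to 160 nM.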

Compound 4, half-maximal inhibitory concentration: 12 nM
Compound 4: middle estimate off by 3.3-fold (0.52 log units), on the high side; low and high end bracket the measured number.
By their numbers in this assay, from the lowest: compound 2; then compounds 4 and 1 (each within the scatter of the next); then compound 3.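

In this assay, taking out the linking carbon of the benzyl gives an 8.5-fold lower number from compound 3 to compound 4 (0.93 log units; beyond the scatter) and recovers much of the loss seen on adding benzyl, so that loss does not follow simply from an aromatic ring on this saturated ring carbon. Even so, phenyl is not neutral at this place: the step of a 6.0-fold higher number from compound 2 to compound 4 (0.78 log units; beyond the scatter) is smaller than the step of a 51-fold higher number from compound 2 to compound 3 (1.71 log units; beyond the scatter) but remains beyond the scatter, and compound 2, with hydrogen there, keeps the lowest number of the three compounds that differ only at this place. No evidence at hand accounts for the difference between phenyl and benzyl.

Going by these compounds, with only hydrogen, phenyl and benzyl at this ring carbon, it remains open whether the number keeps rising as the chain grows, as a phenethyl would show. Also open is whether the aromatic ring itself matters, since the compounds shown include neither a cyclohexyl or methyl on that ring carbon nor a phenyl carrying an amine or a carboxylic acid.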